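Working notes: cyclohexyl for pyrimidin-2-yl on the sulfur

The source may report more compounds than this note shows. Statements on the series, on what has been measured and on what is new or still open speak of the compounds shown alone.

Within the data shown here, compound 1 `O=C(CSc1ncccn1)Nc1ccc2nc(NC(=O)c3ccc(C(F)(F)F)cc3)sc2c1` is the one member of this set that returns a number. In a functional assay on HCT-116 cells (Homo sapiens) for antiproliferative activity, read by MTT assay, with a stated time of 72 h (a higher number here means a weaker inhibitor, a lower number a stronger inhibitor), compound 1 gives 2220 nM, and no other numerical value stands beside it for comparison. Compound 2 `CC(O)c1cccc(NC(=O)c2cc(Br)ccc2Br)c1` reaches only a limit: in this assay compound 2 gives > 100000 nM, a limit of the assay rather than a number. Compound 3 `Cn1c(CNC(=O)c2cccs2)nnc1SCC(=O)Nc1cccc(Cl)c1` behaves the same way, and in this assay compound 3 gives > 100000 nM, also a limit. Two of the three results therefore sit at the limit of > 100000 nM in this assay, at which 2 of the 3 values shown sit, which leaves compound 1 as the sole anchor for any expectation.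

Compound 4 `O=C(CSC1CCCCC1)Nc1ccc2nc(NC(=O)c3ccc(C(F)(F)F)cc3)sc2c1` keeps the core of compound 1 and differs from it in a single place: cyclohexyl in place of pyrimidin-2-yl on a sulfur. Among the measured compounds shown here, no pair of measured compounds shows this change or one like it, so the size of the step cannot be read from the data; the saturated ring replaces an aromatic one on the sulfur, and the step from compound 1 to compound 4 is expected to be small, a 1.6-fold higher number from compound 1 to compound 4 (0.20 log units; within the scatter), leaning toward a weaker inhibitor but possibly within the scatter. Compound 4 is estimated at 3500 nM, with a range from 900 nM to 14000 nM.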

Compound 4, half-maximal inhibitory concentration: 21000 nM
For compound 4 the middle estimate is 6.0-fold (0.78 log units) below the measured one; the whole stated range lies below it.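

Among these compounds, at the sulfur whose other neighbour is a saturated chain carbon, the group is not interchangeable: in this assay, cyclohexyl in place of pyrimidin-2-yl gives a 9.5-fold higher number from compound 1 to compound 4 (0.98 log units; beyond the scatter), the first reading of any change at this position with the rest of the molecule held fixed. Both groups count 6 heavy atoms, so the step does not come with a change in that count; what leaves is a six-membered aromatic ring with 2 hetero atoms and 2 hydrogen-bond acceptors, and what enters is a six-membered non-aromatic ring of carbon only with 0 hydrogen-bond acceptors. Compound 4 still returns a number rather than a limit, but which of these differences carries the step is not settled by any measurement shown here.

The compounds shown leave open whether the ring nitrogens or the aromatic ring itself matter more, a question that phenyl or pyridin-2-yl on the same sulfur would separate. Also open, from the compounds shown here alone, is whether this position needs a ring at all, which a short alkyl chain or a terminal amine there would test.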